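The source may report more compounds than this note shows. Statements on the series, on what has been measured and on what is new or still open speak of the compounds shown alone.

Measured so far in an ADME assay on the whole organism (Rattus norvegicus) for pharmacokinetics, read by LC-MS, at a dose of 1 mg/kg by the intravenous route; a lower number here means slower removal, a higher number faster removal of the compound:
compound 1 `CNC(=O)c1c(-c2ccc(F)cc2)oc2cc(N(Cc3ccc(B(O)O)c(F)c3)S(C)(=O)=O)c(C3CC3)cc12` gives 29 mL/min/kg
compound 2 `CNC(=O)c1c(-c2ccc(F)cc2)oc2cc(N(c3ccc(B(O)O)c(Cl)c3)S(C)(=O)=O)c(C3CC3)cc12` gives 5.1 mL/min/kg

Among the compounds with values here, compound 2 stands at the lower of the two numbers seen in this assay; the only neighbour is compound 1, and the step of a 5.7-fold lower number from compound 1 to compound 2 (0.75 log units; beyond the scatter) is the single measured step in the set.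

Compound 3 `CNC(=O)c1c(-c2ccc(F)cc2)oc2cc(N(Cc3ccc(B(O)O)cc3)S(C)(=O)=O)c(C3CC3)cc12` is not yet measured. It differs from compound 2 by a group of 10 heavy atoms (7 carbon, 1 boron, 2 oxygen; one six-membered aromatic ring of carbon only) in place of a group of 10 heavy atoms (6 carbon, 1 boron, 2 oxygen, 1 chlorine; one six-membered aromatic ring of carbon only), on a sulfonamide nitrogen. Within the data shown here, in words: the group that enters carries one more carbon and no chlorine, so the change runs against the direction of the only measured step, in which one carbon was lost and a chlorine came in with a modest fall in the number. Among the measured compounds shown here, that step is the only guide; no pair with the chlorine removed alone, or the carbon added alone, has been measured, so how the two parts share the effect is unknown.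

On this basis compound 3 is expected to sit above compound 2 in this assay, with an estimated step of a 3.9-fold higher number from compound 2 to compound 3 (0.59 log units; beyond the scatter), most likely back toward the region of compound 1. The estimate for compound 3 is 20 mL/min/kg, with a range from 8 mL/min/kg to 45 mL/min/kg.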

Compound 3, clearance: 36 mL/min/kg
Estimate against measurement, compound 3: 1.8-fold (0.26 log units) below, and the stated range covers the measured number.
By their numbers in this assay, from the lowest: compound 2; then compounds 1 and 3 (each within the scatter of the next).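

In this assay the change of fluoro to hydrogen on an aromatic carbon gives a 1.2-fold higher number from compound 1 to compound 3 (0.09 log units; within the scatter) and so, on this pair, the fluoro does not separate the two compounds. The change of group on the sulfonamide nitrogen gives a 7.1-fold higher number from compound 2 to compound 3 (0.85 log units; beyond the scatter) and thereby sets compound 2 apart from both neighbours: it alone carries the chlorine and the group with one carbon fewer, while the two groups with the further carbon stand together at the higher numbers, with or without fluoro. No measurement in hand bears on the cause of these steps.

Still open, on these data alone, is how the step to compound 2 divides between the chlorine and the lost carbon, a question that a compound holding the chlorine on the group with the further carbon, or a compound with hydrogen on the group with one carbon fewer, would settle. Also open, as far as these compounds go, is whether a methyl or a nitrile in the place of the chlorine would go with a number as low as that of compound 2.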